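The compounds below may be only part of what the source reports. "The series", "measured", "known", "first", "only" and "open" are said of these compounds alone.

Measured compounds in a functional assay (strain AB) with Danio rerio as the target, read by microscopy, with a stated time of 1 h; a higher number here means that more compound is needed for the effect, a lower number that less compound is needed:
- compound 1 `NC(=O)c1c(NC(=O)Nc2ccc(Cl)cc2)sc2c1CCN(C1CCOCC1)C2`: 2830 nM
- compound 2 `CCN1CCc2c(sc(NC(=O)Nc3ccc(Br)cc3)c2C(N)=O)C1`: 3130 nM
- compound 3 `CCN1CCc2c(sc(NC(=O)Nc3ccc(Cl)cc3)c2C(N)=O)C1`: 3120 nM

Compound 3 stands second highest of the three numbers; its neighbours lie close on either side, with a 1.1-fold higher number from compound 1 to compound 3 (0.04 log units; within the scatter) and a 1.0-fold lower number from compound 2 to compound 3 (0.00 log units; within the scatter) both within the scatter, so the three measured compounds are not separated from one another in this assay.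

Compound 4 `CCN1CCc2c(sc(NC(=O)Nc3ccc(Cl)cc3)c2C(=O)NC)C1` differs from compound 3 by methyl in place of hydrogen on an amide-type nitrogen. Neither measured step bears on this position: the step from compound 1 to compound 3 concerns the amine nitrogen in a ring, and the step from compound 2 to compound 3 concerns the aromatic carbon; both were within the scatter and say nothing about the carbamoyl group. The series therefore gives no basis for a directed change, and the expectation is a step within the scatter of compound 3, with a wide range to cover the absence of precedent.

Compound 4 is estimated at 3800 nM, expected between 1300 nM and 12000 nM, a step of a 1.2-fold higher number from compound 3 to compound 4 (0.09 log units; within the scatter).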

Compound 4, half-maximal effective concentration: > 25000 nM
Compound 4: a limit, no number (the forecaster's own chance of this, stated with the estimate: 10%); middle value at least 6.5-fold (0.81 log units) away from the limit.
By their numbers in this assay, from the lowest: compounds 1, 3 and 2 (each within the scatter of the next). At a limit, above all of these: compound 4.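

In this assay compound 4 gives > 25000 nM, which is a limit of the assay and not a number: the limit of > 25000 nM in this assay, at which 1 of the 4 values shown sits.

Methyl in place of hydrogen on the amide-type nitrogen gives an at least 8.0-fold higher number from compound 3 to compound 4 (0.90 log units; beyond the scatter), the only step shown that lies beyond the scatter, whereas the changes on the amine nitrogen in a ring and on the aromatic carbon stayed within it. Among the places varied here, the carbamoyl group is therefore the one where a single small change separates compounds in this assay, and amino to methylamino is not a neutral swap.

As far as these compounds go, how large the step truly is stays open, as does whether it follows from the added methyl or from the missing amide hydrogen. An ethyl group on this nitrogen, a second methyl on it, or a carboxylic acid in place of the carbamoyl group would bear on both questions.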